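This account rests on a few compounds, and the source may have more. Where it says the series, first, only, none or still open, it means among the compounds named here.

Measured in a functional assay on MCF7 cells (Homo sapiens) for antiproliferative activity, with a stated time of 48 h; a lower number here means a stronger inhibitor, a higher number a weaker inhibitor:

compound 1 `CC(C)(C)c1ccc(NC(=O)CCCCl)cc1`, > 100000 nM, a limit of the assay.
compound 2 `CCCCC(O)c1cccc(NC(=O)CCCCl)c1`, > 100000 nM, a limit of the assay.
compound 3 `C=CC(=O)Nc1ccc(C(C)(C)C)cc1`, 29000 nM.

Compound 3 carries vinyl in place of 3-chloropropyl on a carbonyl carbon relative to compound 1, and the step is an at least 3.4-fold lower number from compound 1 to compound 3 (0.53 log units; beyond the scatter). Compound 1 sits at the limit of > 100000 nM in this assay, at which 2 of the 3 values shown sit. Compound 2 sits at that same limit. The cores of compound 1 and compound 2 differ, but that difference is not broken down here. Compound 4 `C=CC(=O)Nc1cccc(C(O)CCCC)c1` is to be measured in this assay; it differs from compound 2 by vinyl in place of 3-chloropropyl on a carbonyl carbon, the same change at the same place. The expected step is an at least 2.5-fold lower number from compound 2 to compound 4 (0.39 log units; beyond the scatter), resting on an at least 3.4-fold lower number from compound 1 to compound 3 (0.53 log units; beyond the scatter) and on compound 3 at 29000 nM. Compound 4 is therefore expected at 40000 nM, within 10000 nM to 150000 nM.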

Compound 4, half-maximal inhibitory concentration: > 100000 nM
Compound 4 gave a limit, no number (the forecaster's own chance of this, stated with the estimate: 35%); middle value at least 2.5-fold (0.39 log units) away from the limit.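

Compound 2 and compound 4 both give only a limit, not a number, so no step between them can be read: the limit of > 100000 nM in this assay, at which 3 of the 4 values shown sit.

The compounds shown leave open whether vinyl in place of 3-chloropropyl lowers the number on the core of compound 2 at all.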